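This account rests on a few compounds, and the source may have more. Where it says the series, first, only, none or still open, it means among the compounds named here.

Of the compounds shown here, three of one family have been measured, and compound 1, with the structure `COc1cc(OC)c(C(=O)/C=C/c2cn(-c3ccccc3)nc2-c2ccsc2)c(OC)c1`, is a useful starting point. In a functional assay on HCT-116 cells (Homo sapiens) for inhibition, read by sulforhodamine B assay, with a stated time of 72 h (on this read-out lower numbers stand for stronger inhibition and higher numbers for weaker inhibition), compound 1 gives 5200 nM. Compound 2, with the structure `COc1ccc(OC)c(C(=O)/C=C/c2cn(-c3ccccc3)nc2-c2ccsc2)c1`, gives 3400 nM in this assay, and compound 3, with the structure `COc1ccc(C(=O)/C=C/c2cn(-c3ccccc3)nc2-c2ccsc2)c(OC)c1`, gives 2200 nM. Among these three numbers compound 1 has the highest, that is, the weakest inhibition; compound 2 sits within the usual scatter of it, while compound 3 lies beyond that scatter, as seen in the step of a 2.4-fold lower number from compound 1 to compound 3 (0.37 log units; beyond the scatter). The step of a 1.5-fold lower number from compound 2 to compound 3 (0.19 log units; within the scatter) stays within the scatter.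

Compound 4, with the structure `COc1cc(OC)c(C(=O)/C=C/c2cn(-c3ccccc3)nc2-c2ccncc2)c(OC)c1`, has not yet been measured. It differs from compound 1 in one place: pyridin-4-yl in place of thiophen-3-yl on an aromatic carbon. Neither measured step touches this part of the shared core; both concern the other end of the molecule, so nothing in the data shows how this assay responds to swapping the thiophen-3-yl group for a pyridin-4-yl group. For the measured compounds named here, with no step bearing on it, the expected change from compound 1 is none beyond the scatter, that is, a 1.0-fold lower number from compound 1 to compound 4 (0.02 log units; within the scatter). Compound 4 is therefore estimated to give 5000 nM in this assay, with a range from 1500 nM to 16000 nM.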

Compound 4, half-maximal inhibitory concentration: 600 nM
The estimate for compound 4 lay 8.3-fold (0.92 log units) above the measured number; measured number below the stated range.
By their numbers in this assay, from the lowest: compound 4; then compounds 3, 2 and 1 (each within the scatter of the next, the first and the last beyond it).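

In this assay, the place on the five-membered aromatic ring that carries thiophen-3-yl in compound 1 proves sensitive to which ring sits there: pyridin-4-yl gives an 8.7-fold lower number from compound 1 to compound 4 (0.94 log units; beyond the scatter), a step beyond the scatter. For the compounds shown here, this is the first measured change at this end of the molecule, and it is larger than a 2.4-fold lower number from compound 1 to compound 3 (0.37 log units; beyond the scatter), the only step at the other end that goes beyond the scatter. Nothing available here says what lies behind the difference, which could involve the change from a five-membered to a six-membered ring, the change from sulfur to nitrogen, or both.

Pyridin-4-yl is shown only alongside the methoxy pattern of compound 1, so it remains open whether the same swap would lower the number as far with the methoxy patterns of compound 2 and compound 3. Also open, as far as these compounds go, is whether the place of the ring nitrogen matters, and a pyridin-3-yl or pyridin-2-yl group on the same aromatic carbon would address that question.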